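Phenylsulfonyl for 3-chlorobenzyl on the propargylamine analogue

The source may hold more compounds than are shown below. What is called first, only, known or untested is meant among the compounds shown, and "the series" means these compounds.

Measured compounds:
compound 1, `C[C@H](NCc1ccc(OCCCCCN2CCN(c3cccc4c3ccn4Cc3cccc(Cl)c3)CC2)cc1)C(N)=O`: > 1000 nM
compound 2, `C[C@H](NCc1ccc(OCCCCCN2CCN(c3cccc4c3ccn4S(=O)(=O)c3ccccc3)CC2)cc1)C(N)=O`: > 1000 nM
compound 3, `C#CCN(C)Cc1ccc(OCCCCCN2CCN(c3cccc4c3ccn4Cc3cccc(Cl)c3)CC2)cc1`: 30 nM

Going by the values given here, in an assay on BTI cells for inhibition of Amine oxidase [flavin-containing] B (Homo sapiens), read by fluorescence, with stated times of 30 min and 1 h (on this read-out higher numbers stand for weaker inhibition and lower numbers for stronger inhibition), compound 3 gives 30 nM, the only number in the set. Compound 1 reports only a limit of the assay, > 1000 nM. Compound 2 likewise reports only a limit, > 1000 nM. Both sit at the limit of > 1000 nM in this assay, at which 2 of the 3 values shown sit. Among the compounds with values here, the step of an at least 33-fold lower number from compound 1 to compound 3 (1.52 log units; beyond the scatter) is the one readable change and is large. The step that the two limits leave unreadable from compound 1 to compound 2 cannot be read, since both ends are limits.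

Compound 4, `C#CCN(C)Cc1ccc(OCCCCCN2CCN(c3cccc4c3ccn4S(=O)(=O)c3ccccc3)CC2)cc1`, differs from compound 3 by phenylsulfonyl in place of 3-chlorobenzyl on an aromatic nitrogen. Within the data shown here, the only measured step bearing on this change is a step that the two limits leave unreadable from compound 1 to compound 2, and it gives no size and no direction. Among the measured compounds shown here, no other pair in the set isolates this change. The expectation for compound 4 therefore rests on compound 3 alone, and the step of a 2.0-fold higher number from compound 3 to compound 4 (0.30 log units; within the scatter) is estimated as small, with wide uncertainty in either direction. Compound 4 is expected at 60 nM, within a range from 15 nM to 400 nM.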

Compound 4, half-maximal inhibitory concentration: 154 nM
Beside the measured number, compound 4's estimate is 2.6-fold (0.41 log units) below it; low and high end bracket the measured number.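

With the methyl(propargyl)amino group in place, the change on the aromatic nitrogen can now be read in this assay: phenylsulfonyl in place of 3-chlorobenzyl gives a 5.1-fold higher number from compound 3 to compound 4 (0.71 log units; beyond the scatter), a modest loss that leaves measurable inhibition. The methyl(propargyl)amino group also keeps its advantage over (1-carbamoylethyl)amino with phenylsulfonyl on that nitrogen, showing an at least 6.4-fold lower number from compound 2 to compound 4 (0.81 log units; beyond the scatter), although the value of compound 2 is only a limit. The size of this advantage can be compared with that seen with 3-chlorobenzyl only in part: the same change on two cores in this assay, an at least 33-fold lower number (1.52 log units; beyond the scatter) from compound 1 to compound 3 and an at least 6.4-fold lower number (0.81 log units; beyond the scatter) from compound 2 to compound 4; the limit leaves it open whether they differ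

As far as these compounds go, the step from compound 1 to compound 2 cannot be read, so the effect of the nitrogen substituent with (1-carbamoylethyl)amino remains open. Also open, from the compounds shown here alone, is how a methanesulfonyl group or an unsubstituted benzyl group on the aromatic nitrogen would rank against 3-chlorobenzyl and phenylsulfonyl.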